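The source may report more compounds than this note shows. Statements on the series, on what has been measured and on what is new or still open speak of the compounds shown alone.

Compound 1 `COCOc1cc(/C=C/C(=O)OCC(=O)Nc2ccc(OC)cc2)ccc1OCc1ccccc1` — in a functional assay on LS174T cells (Homo sapiens) for cytotoxicity, read by MTT assay, with a stated time of 72 h (on this read-out lower numbers stand for stronger inhibition and higher numbers for weaker inhibition), compound 1 gives > 200000 nM, which is a limit of the assay and not a number.
Compound 2 `COCOc1cc(/C=C/C(=O)OCC(=O)Nc2ccc(Cl)cc2)ccc1OCc1ccccc1` — in this assay compound 2 gives > 200000 nM, again a limit rather than a number.
Compound 3 `COc1ccc(NC(=O)COC(=O)/C=C/c2cc(OC)c(OCc3ccc(Cl)c(Cl)c3)c(OC)c2)cc1` — in this assay compound 3 gives > 200000 nM, also a limit.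

The change from compound 1 to compound 2 is chloro in place of methoxy on an aromatic carbon, and its size is a step that the two limits leave unreadable from compound 1 to compound 2, since both values sit at the limit of > 200000 nM in this assay, at which 3 of the 3 values shown sit. Compound 4 `COc1cc(/C=C/C(=O)OCC(=O)Nc2ccc(Cl)cc2)cc(OC)c1OCc1ccc(Cl)c(Cl)c1` has not yet been measured. Compound 4 arises from compound 3 by chloro in place of methoxy on an aromatic carbon, the same change, at the same place word for word. The difference between the core of compound 1 and the core of compound 3 is not broken down here. Because all three measured compounds sit at the limit of > 200000 nM in this assay, at which 3 of the 3 values shown sit, the step from compound 3 to compound 4 is expected to be a step that the limit leaves unreadable from compound 3 to compound 4, most likely ending at a limit again. Compound 4 is therefore estimated at 300000 nM, between 150000 nM and 1000000 nM.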

Compound 4, half-maximal inhibitory concentration: 72400 nM
For compound 4 the middle estimate is 4.1-fold (0.62 log units) above the measured one; measured number below the stated range.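

In this assay, chloro in place of methoxy on the core of compound 3 gives an at least 2.7-fold lower number from compound 3 to compound 4 (0.44 log units; beyond the scatter), so on this core the change turns a limit into a measurable number. Going by these compounds, the true size of this step remains unknown: the value of compound 3 is a limit and not a number. The same change on the core of compound 1 cannot be read, and with only this one readable pair, nothing shows that the change carries over from one core to the other: the limit of > 200000 nM in this assay, at which 3 of the 4 values shown sit.

The compounds shown carry only methoxy or chloro at this place on the phenyl ring. On these data alone, how an amine or a carboxylic acid would read there remains open, on either core.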